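A few compounds are considered here, and "the series" means these few. Any claim that something is new, unique, unknown or untested is made for them only; others in the source may bear on it.

Compound 1 `O=C(C/C=C/c1ccccc1)Nc1nc2ccccc2c(=O)s1` is tested in an assay on mitochondria (strain Sprague-Dawley) for inhibition of Amine oxidase [flavin-containing] B (Rattus norvegicus), read by fluorescence and Amplex Red, with stated times of 30 min and 45 min (on this read-out higher numbers stand for weaker inhibition and lower numbers for stronger inhibition), where compound 1 gives 361 nM. That number stands highest of the two values reported in this assay: compound 2 `COc1cccc(C#CC(=O)Nc2nc3ccccc3c(=O)s2)c1` gives 73.9 nM, and the gap between the two lies beyond the scatter. Compound 3 `O=C(CCCc1ccccc1)Nc1nc2ccc(Br)cc2c(=O)s1` is reported only as a limit and not as a number, at > 10000 nM, which is the limit of > 10000 nM in this assay, at which 1 of the 3 values shown sits. Compound 4 `COc1cccc(/C=C/CC(=O)Nc2nc3ccccc3c(=O)s2)c1` has not yet been measured in this assay. It differs from compound 1 in one place: methoxy in place of hydrogen on an aromatic carbon. For the measured compounds named here, no measured pair shows this change on its own, so the step expected here, a 1.8-fold lower number from compound 1 to compound 4 (0.26 log units; within the scatter), is a modest one toward a lower number, possibly within the scatter. Compound 4 is therefore estimated at 200 nM in this assay, between 70 nM and 600 nM.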

Compound 4, half-maximal inhibitory concentration: 2020 nM
The estimate for compound 4 lay 10-fold (1.00 log units) below the measured number; the whole stated range lies below it.
By their numbers in this assay, from the lowest: compound 2; then compound 1; then compound 4. At a limit, above all of these: compound 3.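

In this assay, adding this one group to the aromatic ring gives a step beyond the scatter: going from phenyl to 3-methoxyphenyl brings a 5.6-fold higher number from compound 1 to compound 4 (0.75 log units; beyond the scatter). This aromatic carbon is therefore sensitive to substitution, and on this chain methoxy weakens inhibition rather than strengthening it. Nothing measured here bears on why the step runs this way. As far as these compounds go, what a hydroxyl or a chlorine would do at the same carbon stays open, as does whether methoxy has the same effect on the alkyne chain of compound 2.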